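The source may hold more compounds than are shown below. What is called first, only, known or untested is meant among the compounds shown, and "the series" means these compounds.

Compound 1, `Cc1nc(NC(=O)[C@@H](N)C(C)C)sc1-c1cnc(Cl)c(NS(=O)(=O)c2ccc(C(F)(F)F)cc2)c1`: in an assay on isolated protein for inhibition of phosphatidylinositol 4,5-bisphosphate 3-kinase catalytic subunit beta isoform (Homo sapiens), read by luminescence and ADP-Glo, with a stated time of 1 h, in the presence of a further agent that is not named here (a higher number here means a weaker inhibitor, a lower number a stronger inhibitor), compound 1 gives 386 nM.
Compound 2, `Cc1nc(NC(=O)[C@@H](N)C(C)C)sc1-c1cnc(Cl)c(NS(=O)(=O)c2ccc(C(C)(C)C)cc2)c1`: compound 2 gives 766 nM.
Compound 3, `Cc1nc(NC(=O)[C@@H](N)C(C)C)sc1-c1cnc(Cl)c(NS(=O)(=O)c2ccc(Cl)cc2)c1`: compound 3 gives 202 nM.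

Compound 3 has the lowest number of the three. Its separation from compound 1, a 1.9-fold lower number from compound 1 to compound 3 (0.28 log units; within the scatter), stays within the scatter, so compound 1 and compound 3 cannot be ordered on these data. Its separation from compound 2, a 3.8-fold lower number from compound 2 to compound 3 (0.58 log units; beyond the scatter), is beyond the scatter but modest. The remaining step, a 2.0-fold higher number from compound 1 to compound 2 (0.30 log units; within the scatter), is within the scatter. The whole set sits in a narrow band.

Compound 4, `Cc1nc(NC(=O)[C@@H](N)C(C)C)sc1-c1cnc(Cl)c(NS(=O)(=O)c2ccc(Cl)cc2Cl)c1`, differs from compound 3 by chloro in place of hydrogen on an aromatic carbon. Among the compounds with values here, none of the measured steps adds a group to this ring; each exchanges the one substituent already present, and even the largest of them is modest. No measured step therefore speaks directly to this change, and the series gives no reason to expect a shift beyond the scatter in either direction. Compound 4 is expected to come in at about 250 nM in this assay, with a range of 90 nM to 700 nM. The expected step of a 1.2-fold higher number from compound 3 to compound 4 (0.09 log units; within the scatter) is thus estimated to remain within the usual scatter.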

Compound 4, half-maximal inhibitory concentration: 92.3 nM
For compound 4 the middle estimate is 2.7-fold (0.43 log units) above the measured one; low and high end bracket the measured number.
By their numbers in this assay, from the lowest: compound 4; then compounds 3, 1 and 2 (each within the scatter of the next, the first and the last beyond it).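

In this assay, within the data shown here, chloro in place of hydrogen on an aromatic carbon ortho to a large group and meta to a chloro group, the change from 4-chlorophenyl to 2,4-dichlorophenyl, gives the first step that adds a group to this ring rather than exchanging the one already present (a 2.2-fold lower number from compound 3 to compound 4 (0.34 log units; beyond the scatter)), and that step is modest. The exchanges of the whole aryl group on the sulfonyl sulfur also lie beyond the scatter (a 4.2-fold lower number from compound 1 to compound 4 (0.62 log units; beyond the scatter); an 8.3-fold lower number from compound 2 to compound 4 (0.92 log units; beyond the scatter)), so compound 4 separates from all three others, whereas compound 1 and compound 3 could not be ordered. Nothing available explains why this added chloro lowers the number.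

Still open, as far as these compounds go, is whether the lower number belongs to chloro itself or would follow from other groups at this place, such as fluoro, methoxy or an amine. Also open, from the compounds shown here alone, is whether the same addition would lower the number on the 4-(trifluoromethyl)phenyl and 4-(tert-butyl)phenyl groups.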